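Third methoxy on the pendant group of compound 3

A few compounds are considered here, and "the series" means these few. Any claim that something is new, unique, unknown or untested is made for them only; others in the source may bear on it.

Three compounds share one core and differ only in the group on a saturated ring carbon. Compound 1 `Cc1cc(O)c(C2=NN(c3ccc(S(N)(=O)=O)cc3)C(c3ccccc3O)C2)cc1Cl` carries 2-hydroxyphenyl there, and in a functional assay on SF-539 cells (Homo sapiens) for antiproliferative activity, with a stated time of 48 h (on this read-out higher numbers stand for weaker inhibition of growth and lower numbers for stronger inhibition of growth), compound 1 gives 3020 nM. Compound 2 `Cc1cc(O)c(C2=NN(c3ccc(S(N)(=O)=O)cc3)C(/C=C/c3ccccc3)C2)cc1Cl` carries 2-phenylethenyl, and in this assay compound 2 gives 14000 nM; the step of a 4.6-fold higher number from compound 1 to compound 2 (0.67 log units; beyond the scatter) lies beyond the scatter. Compound 3 `COc1ccc(C2CC(c3cc(Cl)c(C)cc3O)=NN2c2ccc(S(N)(=O)=O)cc2)cc1OC` carries 3,4-dimethoxyphenyl, and in this assay compound 3 gives 4750 nM, the second highest of the three numbers; a 1.6-fold higher number from compound 1 to compound 3 (0.20 log units; within the scatter) stays within the scatter, while a 2.9-fold lower number from compound 2 to compound 3 (0.47 log units; beyond the scatter) lies beyond it.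

Compound 4 `COc1ccc(C2CC(c3cc(Cl)c(C)cc3O)=NN2c2ccc(S(N)(=O)=O)cc2)c(OC)c1OC` differs from compound 3 by methoxy in place of hydrogen on an aromatic carbon, the group on the saturated ring carbon going from 3,4-dimethoxyphenyl to 2,3,4-trimethoxyphenyl. Among the measured compounds shown here, no measured step adds a single substituent to this group; the measured steps exchange the whole group, and the one that reaches compound 3 from compound 1 stays within the scatter. On this basis the step of a 1.1-fold higher number from compound 3 to compound 4 (0.02 log units; within the scatter) is expected to stay within the scatter in this assay, with no clear direction. Compound 4 is therefore estimated at 5000 nM in this assay, within 2000 nM to 13000 nM.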

Compound 4, concentration for total growth inhibition: 3370 nM
For compound 4 the middle estimate is 1.5-fold (0.17 log units) above the measured one; measured number inside the range.
By their numbers in this assay, from the lowest: compounds 1, 4 and 3 (each within the scatter of the next); then compound 2.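

In this assay, among the compounds shown here, methoxy in place of hydrogen on an aromatic carbon, ortho to a large group, gives the first single-substituent change on this pendant group, and a 1.4-fold lower number from compound 3 to compound 4 (0.15 log units; within the scatter) shows no clear response to it. The 2,3,4-trimethoxyphenyl group matches the earlier pattern, with a 1.1-fold higher number from compound 1 to compound 4 (0.05 log units; within the scatter) staying within the scatter and a 4.2-fold lower number from compound 2 to compound 4 (0.62 log units; beyond the scatter) lying beyond it, so among the four compounds only compound 2, with 2-phenylethenyl, stands apart. Nothing available explains this tolerance to an added methoxy.

The compounds shown leave open whether an amine or a carboxylic acid in place of this methoxy, or a longer chain on the same oxygen, would also stay within the scatter of compound 3. As far as these compounds go, whether removing the other two methoxy groups changes the number also remains open.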